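Benzyl ether replacing ethyl ether on two bicyclic amine cores

The source may report more compounds than this note shows. Statements on the series, on what has been measured and on what is new or still open speak of the compounds shown alone.

Measured values in an assay on HEK293 cells for displacement of a labelled ligand from Neuronal acetylcholine receptor; alpha4/beta4 (Rattus norvegicus), with a stated time of 4 h; on this read-out higher numbers stand for weaker inhibition and lower numbers for stronger inhibition:
Compound 1 `CCO[C@H]1CC[C@H]2CCN(C)[C@H]2C1`: > 300000 nM, a limit of the assay.
Compound 2 `CN1CC[C@@H]2CC[C@H](OCc3ccccc3)C[C@@H]21`: 300000 nM.
Compound 3 `CCO[C@H]1CC=C2CCN(C)[C@H]2C1`: > 300000 nM, a limit of the assay.

The difference between the core of compound 1 and the core of compound 3 is not broken down here. On these data alone, the step of a number no higher from compound 1 to compound 2 (the limit leaves the size open) comes from the change (phenyl in place of methyl on a saturated chain carbon bound to an oxygen on a saturated carbon); its size stays open because compound 1 sits at the limit of > 300000 nM in this assay, at which 2 of the 3 values shown sit. Compound 4 `CN1CCC2=CC[C@H](OCc3ccccc3)C[C@@H]21` is not yet measured; it differs from compound 3 by phenyl in place of methyl on a saturated chain carbon bound to an oxygen on a saturated carbon, the same change at the same place.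

Compound 4 is expected at 300000 nM, with a range from 100000 nM to 1000000 nM, most likely reported again as a limit. The expected step of a number no higher from compound 3 to compound 4 (the limit leaves the size open) is estimated as flat. This rests on compound 2, which gives 300000 nM.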

Compound 4, inhibition constant: 300000 nM
The estimate for compound 4 equals the measured number at the digits printed; the measured number falls inside the stated range.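

In this assay, phenyl in place of methyl on a saturated chain carbon bound to an oxygen on a saturated carbon gives a number no higher from compound 3 to compound 4 (the limit leaves the size open). This change reads alike on the two cores: the same change on two cores in this assay, a number no higher (the limit leaves the size open) from compound 1 to compound 2 and a number no higher (the limit leaves the size open) from compound 3 to compound 4; the limit leaves it open whether they differ

Neither step can be read as a size, since the values of compound 1 and compound 3 are limits of the assay and not numbers: the limit of > 300000 nM in this assay, at which 2 of the 4 values shown sit.

The change thus carries from one core to the other without any conflict in direction, but nothing shows that it is worth the same amount on each core.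

Open, on these data alone, is whether an amine or a carboxylic acid on the ether chain would give a value clear of this limit. The same question stands for a longer chain.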